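The source may hold more compounds than are shown below. What is called first, only, known or untested is meant among the compounds shown, and "the series" means these compounds.

Compound 1, with the structure `COC(=O)c1nc(C)n(-c2ccccc2)n1`, is the reference point of this account. In a functional assay on Jurkat cells (Homo sapiens) for inhibition, read by MTT assay, with a stated time of 72 h (a higher number here means a weaker inhibitor of growth, a lower number a stronger inhibitor of growth), compound 1 gives > 100000 nM, which is a limit of the assay rather than a measured number. Two measured analogues replace a hydrogen on an aromatic carbon of the shared core. Compound 2, `COC(=O)c1nc(C)n(-c2cccc(C(F)(F)F)c2)n1`, gives 10600 nM in this assay. The corresponding step is an at least 9.4-fold lower number from compound 1 to compound 2 (0.97 log units; beyond the scatter). Compound 3, `COC(=O)c1nc(C)n(-c2ccc(Cl)cc2)n1`, gives 65900 nM in this assay. That step is an at least 1.5-fold lower number from compound 1 to compound 3 (0.18 log units; that floor lies within the scatter). The unmeasured compound 4, `COC(=O)c1nc(C)n(-c2ccc(F)cc2)n1`, differs from compound 1 by fluoro in place of hydrogen on an aromatic carbon. Both measured steps bear on this change, since each puts a single substituent onto an aromatic carbon in place of a hydrogen; the trifluoromethyl step was at least modest, while the chloro step, with fluoro the closer relative as a single halogen atom, had a floor lying within the scatter. A step no larger than that of compound 3 is therefore expected, and because compound 1 sits at the limit of > 100000 nM in this assay, at which 1 of the 3 values shown sits, even a small lowering could leave compound 4 at the limit as well. Compound 4 is expected to give 100000 nM in this assay, with a range from 30000 nM to 300000 nM. The expected step is a number no higher from compound 1 to compound 4 (the limit leaves the size open).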

Compound 4, concentration for 50% growth inhibition: 8700 nM
Compound 4: middle estimate off by 11-fold (1.06 log units), on the high side; the measured number lies below the stated range.
By their numbers in this assay, from the lowest: compounds 4 and 2 (each within the scatter of the next); then compound 3. At a limit, above all of these: compound 1.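

In this assay, fluoro in place of hydrogen on the aromatic carbon para to a large group gives an at least 11-fold lower number from compound 1 to compound 4 (1.06 log units; beyond the scatter) and so shows that a single fluorine atom at this position is enough for a large step, which the chloro analogue had not shown. The two halogens at this same place also give clearly different results, since fluoro in place of chloro gives a 7.6-fold lower number from compound 3 to compound 4 (0.88 log units; beyond the scatter) and this gap lies beyond the scatter, a comparison that could not be made while chloro was the only halogen at hand. The full size of the step from hydrogen remains unknown because compound 1 stands at a limit of the assay rather than at a measured number: the limit of > 100000 nM in this assay, at which 1 of the 4 values shown sits.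

The compounds shown leave open whether a bromine atom, a methoxy group or an amine at this same place would follow fluoro or chloro, and whether fluoro on the other aromatic carbons of the six-membered ring would give a step of similar size. They also leave open how a carboxylic acid or an amide in place of the methyl ester would act alongside the fluoro group.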